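From 4-chlorophenyl to 3-methoxyphenyl

The compounds below may be only part of what the source reports. "The series", "measured", "known", "first", "only" and "open" are said of these compounds alone.

Measured so far in a functional assay on K562 cells (Homo sapiens) for antiproliferative activity, read by CCK-8 assay, with a stated time of 72 h; a lower number here means a stronger inhibitor, a higher number a weaker inhibitor:
Compound 1 `Cc1cc(Nc2cc(N3CCN(C)CC3)nc(Nc3ccc(S(N)(=O)=O)cc3)n2)n[nH]1` gives 1430 nM
Compound 2 `Cc1cc(Nc2cc(N3CCN(C)CC3)nc(Nc3ccc([N+](=O)[O-])cc3)n2)n[nH]1` gives 137 nM
Compound 3 `Cc1cc(Nc2cc(N3CCN(C)CC3)nc(Nc3ccc(Cl)cc3)n2)n[nH]1` gives 192 nM

Compound 3 sits with one measured neighbour and apart from the other. The data show a 1.4-fold higher number from compound 2 to compound 3 (0.15 log units; within the scatter), and they also show a 7.4-fold lower number from compound 1 to compound 3 (0.87 log units; beyond the scatter). The compound still to be measured, compound 4 `COc1cccc(Nc2nc(Nc3cc(C)[nH]n3)cc(N3CCN(C)CC3)n2)c1`, differs from compound 3 at a single place: 3-methoxyphenyl in place of 4-chlorophenyl on a nitrogen on an aromatic ring. In words, 3-methoxyphenyl stands in place of 4-chlorophenyl on a nitrogen on an aromatic ring.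

Going by the values given here, all the measured steps change one group on an aromatic carbon of this same aryl unit, but none of them introduces methoxy or tests this exact exchange. Two points bear on it. Replacing the sulfamoyl group of compound 1 gave a large drop, seen in a 10-fold lower number from compound 1 to compound 2 (1.02 log units; beyond the scatter), so this part of the molecule can matter. Yet compound 2 and compound 3 show no change beyond the scatter, despite carrying different groups. A sizeable step is therefore not expected, though a slight upward lean seems reasonable. The expected step in this assay is a 1.6-fold higher number from compound 3 to compound 4 (0.19 log units; within the scatter). Compound 4 is estimated at 300 nM, with an expected range from 100 nM to 900 nM.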

Compound 4, half-maximal inhibitory concentration: 509 nM
The estimate for compound 4 lay 1.7-fold (0.23 log units) below the measured number, and the stated range covers the measured number.
By their numbers in this assay, from the lowest: compounds 2 and 3 (each within the scatter of the next); then compound 4; then compound 1.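

In this assay, the aryl group on this nitrogen moved the number beyond the scatter even without the sulfamoyl group being involved: 3-methoxyphenyl in place of 4-chlorophenyl gave a 2.7-fold higher number from compound 3 to compound 4 (0.42 log units; beyond the scatter), and 3-methoxyphenyl in place of 4-nitrophenyl gave a 3.7-fold higher number from compound 2 to compound 4 (0.57 log units; beyond the scatter), whereas compound 2 and compound 3 had stood within the scatter of each other. The new group still compares well with 4-sulfamoylphenyl, with a 2.8-fold lower number from compound 1 to compound 4 (0.45 log units; beyond the scatter), so the four aryl groups shown now fall into three levels, with 3-methoxyphenyl on the middle one. No measured evidence is at hand to explain this shift.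

The compounds shown carry methoxy only in 3-methoxyphenyl and chloro only in 4-chlorophenyl, so they do not separate the contribution of the group itself from that of its place on the ring. They also leave open how an amine or a carboxylic acid on this aryl unit would read in this assay.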